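Swapping the Amide Side Group on a Cholesterol Transporter Binder

The source may hold more compounds than are shown below. What is called first, only, known or untested is meant among the compounds shown, and "the series" means these compounds.

Compound 1 `O=C(CN1CN(c2ccccc2)C2(CCN(C(=O)c3ccc(C4CCCCC4)cc3)CC2)C1=O)N1CCC(CO)CC1` holds the lower of the two reported numbers in an assay on HEK293 cells for displacement of a labelled ligand from NPC1-like intracellular cholesterol transporter 1 (Homo sapiens); on this read-out lower numbers stand for stronger inhibition and higher numbers for weaker inhibition: compound 1 gives 1100 nM. Compound 3 `CC(C)(C)c1ccc(C(=O)N2CCC3(CC2)C(=O)N(CC(=O)N2CCCCC2CCO)CN3c2ccccc2)cc1` gives 6100 nM in this assay, a higher number that lies beyond the usual scatter, so compound 1 is the stronger of the two. Compound 2 `CCc1nn(CC)c(C2CCN(C(=O)CN3CN(c4ccccc4)C4(CCN(C(=O)c5ccc(C6CCCCC6)cc5)CC4)C3=O)CC2)c1C` belongs to the same series, but in this assay compound 2 gives "not determined" (no result reported), so no result was reported for it. Compound 3 differs from compound 1 in more than one place, so its weaker result cannot be traced to any single change.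

Compound 4 `CCOC(=O)C1CCCN(C(=O)CN2CN(c3ccccc3)C3(CCN(C(=O)c4ccc(C5CCCCC5)cc4)CC3)C2=O)C1` differs from compound 1 in exactly one place: 3-(ethoxycarbonyl)piperidin-1-yl in place of 4-(hydroxymethyl)piperidin-1-yl on a carbonyl carbon. Going by the values given here, no measured pair carries this particular change, so the direction of the step rests on expectation alone. The group that leaves carries a hydrogen-bond donor; the group that enters carries none and is somewhat larger. A mild weakening is expected: the step from compound 1 to compound 4 is estimated at a 1.8-fold higher number from compound 1 to compound 4 (0.26 log units; within the scatter), close to the edge of the scatter. Compound 4 is therefore expected to give about 2000 nM in this assay, within a range from 700 nM to 6000 nM.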

Compound 4, half-maximal inhibitory concentration: 4200 nM
For compound 4 the middle estimate is 2.1-fold (0.32 log units) below the measured one, and the stated range covers the measured number.
By their numbers in this assay, from the lowest: compound 1; then compounds 4 and 3 (each within the scatter of the next).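

Going by these compounds alone, this is the first step with a single change, so the difference in this assay can be placed at the carbonyl carbon: 3-(ethoxycarbonyl)piperidin-1-yl in place of 4-(hydroxymethyl)piperidin-1-yl gives a 3.8-fold higher number from compound 1 to compound 4 (0.58 log units; beyond the scatter). The group at this place therefore matters to the read-out, and this swap costs a modest amount of inhibition. Still, the change is a bundle, as the entering group is larger, lacks the hydrogen-bond donor, and carries its side chain at a different ring number, and no supporting measurement shows which of these counts.

The compounds shown leave open whether the ester or the new ring number accounts for the step. A 3-(hydroxymethyl)piperidin-1-yl group or a 4-(ethoxycarbonyl)piperidin-1-yl group on the same carbonyl carbon would pull the two apart.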